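The source may report more compounds than this note shows. Statements on the series, on what has been measured and on what is new or still open speak of the compounds shown alone.

compound 1 `CC(C)C[C@H](NC(=O)CSc1cc(NS(=O)(=O)c2ccc(Cl)cc2)c2ccccc2c1O)B(O)O`: 6900 nM
compound 2 `CC(C)C[C@H](NC(=O)CCSc1cc(NS(=O)(=O)c2ccccc2)c2ccccc2c1O)B(O)O`: 7800 nM

In a functional assay on A549 cells (Homo sapiens) for antiproliferative activity, read by sulforhodamine B assay, with a stated time of 72 h (on this read-out lower numbers stand for stronger inhibition and higher numbers for weaker inhibition), compound 2, at 7800 nM, lies within the scatter of compound 1, at 6900 nM. Compound 3 `CC(C)C[C@H](NC(=O)CCSc1cc(NS(=O)(=O)c2ccc(Cl)cc2)c2ccccc2c1O)B(O)O` has not yet been measured. It derives from compound 2 by chloro in place of hydrogen on an aromatic carbon, para to a large group, turning phenylsulfonyl into (4-chlorophenyl)sulfonyl.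

For the measured compounds named here, no measured pair differs in one place only, so the series offers no direct precedent for this change. Compound 1, at 6900 nM, already carries (4-chlorophenyl)sulfonyl and still sits within the scatter of compound 2, so no step beyond the scatter is expected in this assay. The estimated 1.3-fold lower number from compound 2 to compound 3 (0.11 log units; within the scatter) is accordingly small. For compound 3 the expected value is 6000 nM, with an estimated range of 2800 nM to 13000 nM.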

Compound 3, half-maximal inhibitory concentration: 8100 nM
For compound 3 the middle estimate is 1.4-fold (0.13 log units) below the measured one; the range from low to high includes it.
By their numbers in this assay, from the lowest: compounds 1, 2 and 3 (each within the scatter of the next).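

In this assay, for the compounds shown here, a 1.0-fold higher number from compound 2 to compound 3 (0.02 log units; within the scatter) gives the first direct reading of chloro in place of hydrogen on an aromatic carbon, para to a large group, and turning phenylsulfonyl into (4-chlorophenyl)sulfonyl leaves the number within the scatter. With (4-chlorophenyl)sulfonyl held fixed, a 1.2-fold higher number from compound 1 to compound 3 (0.07 log units; within the scatter) shows that the change of group on a saturated chain carbon bound to a sulfur also stays within the scatter, so neither single change separates these compounds here. Nothing at hand explains the absence of a step at either place.

Going by these compounds, whether an amine or a carboxylic acid at the same aromatic carbon would move the number remains open, as does the effect of a longer chain on the sulfur. The compounds shown also leave open whether these two changes stay silent in any read-out other than this assay.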